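Methoxy to ethoxy on the biaryl of compound 2

The source may report more compounds than this note shows. Statements on the series, on what has been measured and on what is new or still open speak of the compounds shown alone.

Measured so far in a functional assay on CHO cells for agonist activity at Free fatty acid receptor 1 (Homo sapiens), read by FLIPR and calcium flux; on this read-out higher numbers stand for an effect only at larger amounts of compound and lower numbers for an effect already at smaller amounts:
compound 1 `COc1ccc(C)c(-c2cccc(COc3ccc(OCC(=O)O)c(F)c3)c2)c1`: 260 nM
compound 2 `COc1cccc(-c2cccc(COc3ccc(OCC(=O)O)c(F)c3)c2)c1`: 540 nM

Going by the values given here, compound 2 stands at the higher of the two numbers in this assay ; its nearest neighbour is compound 1, and the only measured step is a 2.1-fold higher number from compound 1 to compound 2 (0.32 log units; beyond the scatter), a modest move that comes from a hydrogen in place of a methyl on an aromatic carbon.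

Compound 3 `CCOc1cccc(-c2cccc(COc3ccc(OCC(=O)O)c(F)c3)c2)c1` is the next member. It differs from compound 2 by methyl in place of hydrogen on a saturated chain carbon bound to an oxygen on an aromatic ring; the difference is small in what it adds and sits on the chain carbon bound to the aromatic oxygen, not on a ring carbon. Among the compounds with values here, no measured step touches that position, so the step from compound 1 to compound 2 bears on it only as a gauge of how much a single carbon has moved this assay so far, which was modest.

Within the data shown here, with no direct precedent, compound 3 is expected to move by a 1.2-fold lower number from compound 2 to compound 3 (0.08 log units; within the scatter) at most, a change that may well fall within the scatter.

Compound 3 is therefore estimated at 450 nM in this assay, with a range from 200 nM to 1200 nM.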

Compound 3, half-maximal effective concentration: 480 nM
The estimate for compound 3 lay 1.1-fold (0.03 log units) below the measured number; measured number inside the range.
By their numbers in this assay, from the lowest: compounds 1, 3 and 2 (each within the scatter of the next, the first and the last beyond it).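

In this assay, methoxy to ethoxy gives a 1.1-fold lower number from compound 2 to compound 3 (0.05 log units; within the scatter), so the one added methyl on the saturated chain carbon bound to an oxygen on an aromatic ring produces no difference that this read-out can separate. The larger exchange of 3-ethoxyphenyl in place of 5-methoxy-2-methylphenyl gives a 1.8-fold higher number from compound 1 to compound 3 (0.27 log units; within the scatter), which also stays inside the scatter; compound 3 therefore cannot be told apart from either compound 1 or compound 2, even though those two are separated by a 2.1-fold higher number from compound 1 to compound 2 (0.32 log units; beyond the scatter). No supporting data bear on these numbers, so the result stands as an observation without an explanation.

Going by these compounds, it remains open whether this tolerance extends beyond ethoxy to a longer chain such as propoxy, a branched isopropoxy or a cyclopropylmethoxy group, or to a hydroxyl or an amine at the same place. On these data alone, it also remains open whether the methyl on the aromatic carbon that separates compound 1 from compound 2 would give a comparable step when paired with ethoxy instead of methoxy.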